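A few compounds are considered here, and "the series" means these few. Any claim that something is new, unique, unknown or untested is made for them only; others in the source may bear on it.

Compound 1 `CN(C)CCn1cnnc1-c1cc(Oc2ccc(NC(=O)N/N=C/c3c(Cl)cccc3Cl)cc2F)ccn1` gives 280 nM in a functional assay on HT-29 cells (Homo sapiens) for cytotoxicity, read by MTT assay, with a stated time of 72 h; on this read-out lower numbers stand for stronger inhibition and higher numbers for weaker inhibition.
Compound 2 `COc1ccc(/C=N/NC(=O)Nc2ccc(Oc3ccnc(-c4nncn4CCN(C)C)c3)c(F)c2)c(OC)c1OC` gives 3970 nM in this assay.
Compound 3 `COc1ccc(/C=N/NC(=O)Nc2ccc(Oc3ccnc(-c4nncn4CCN(C)C)c3)c(F)c2)cc1O` gives 960 nM in this assay.

Compound 1 has the lowest number of the three measured compounds in this assay; compound 3 is nearest to it and compound 2 furthest. Compound 4 `Cc1cc(/C=N/NC(=O)Nc2ccc(Oc3ccnc(-c4nncn4CCN(C)C)c3)c(F)c2)cc(C)c1O` differs from compound 1 only at the aryl group on the carbon with a double bond to nitrogen: 4-hydroxy-3,5-dimethylphenyl in place of 2,6-dichlorophenyl on a carbon with a double bond to nitrogen.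

Among the compounds with values here, two measured steps bear on this change, both replacing the same 2,6-dichlorophenyl at the same place. There is a 14-fold higher number from compound 1 to compound 2 (1.15 log units; beyond the scatter) and a 3.4-fold higher number from compound 1 to compound 3 (0.54 log units; beyond the scatter). Both exchanges give higher numbers in this assay, the modest one with 3-hydroxy-4-methoxyphenyl and the large one with 2,3,4-trimethoxyphenyl; within that pair, a 4.1-fold lower number from compound 2 to compound 3 (0.62 log units; beyond the scatter). The 4-hydroxy-3,5-dimethylphenyl of compound 4 carries a single hydroxy like compound 3 rather than three methoxy groups, so a step of the modest kind is expected, upward in number, beyond the scatter, as in a 2.7-fold higher number from compound 1 to compound 4 (0.43 log units; beyond the scatter). Compound 4 is therefore estimated at 750 nM in this assay, with a range from 250 nM to 2200 nM.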

Compound 4, half-maximal inhibitory concentration: 1220 nM
Beside the measured number, compound 4's estimate is 1.6-fold (0.21 log units) below it; the range from low to high includes it.
By their numbers in this assay, from the lowest: compound 1; then compounds 3 and 4 (each within the scatter of the next); then compound 2.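

In this assay there is a 1.3-fold higher number from compound 3 to compound 4 (0.10 log units; within the scatter) and so 4-hydroxy-3,5-dimethylphenyl and 3-hydroxy-4-methoxyphenyl cannot be told apart here, even though they differ in the groups they carry besides the hydroxy. With a 4.4-fold higher number from compound 1 to compound 4 (0.64 log units; beyond the scatter) and a 3.3-fold lower number from compound 2 to compound 4 (0.51 log units; beyond the scatter) the picture at this position gains a second hydroxy-bearing aryl group, and both such groups give higher numbers than 2,6-dichlorophenyl and lower numbers than 2,3,4-trimethoxyphenyl, a pattern that no compound shown goes against. Nothing available on these compounds explains this order.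

Within the data shown here, no single-change pair here separates the contribution of the hydroxy from that of the methyl or methoxy groups, nor that of the two chlorine atoms from that of the aryl ring itself. On these data alone, how unsubstituted phenyl, or an aryl group carrying an amine or a carboxylic acid, would fare at this position remains open.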